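The source may hold more compounds than are shown below. What is called first, only, known or untested is meant among the compounds shown, and "the series" means these compounds.

In a functional assay on MV4-11 cells (Homo sapiens) for antiproliferative activity, with a stated time of 48 h (a higher number here means a weaker inhibitor, a lower number a stronger inhibitor), compound 1 `CCCNNC(=O)c1ccc(CNC(=O)c2ccc3ccccc3n2)cc1` gives 57.8 nM and compound 2 `C=CCOc1ccc2oc(C(=O)NCc3ccc(C(=O)NNCCC)cc3)cc2c1` gives 53.8 nM while compound 3 `CCCNNC(=O)c1ccc(CNC(=O)c2cc3cc(Cl)ccc3[nH]2)cc1` gives 37.7 nM on the same read-out. Compound 2 stands within the scatter of both other compounds, so its number is not separated from either of them. For the measured compounds named here, no two measured compounds differ in one place only, so the series holds no direct reading of the change under consideration. Compound 4 `CCCNNC(=O)c1ccc(CNC(=O)c2cc3cc(OC)ccc3o2)cc1` departs from compound 2 by hydrogen in place of vinyl on a saturated chain carbon bound to an oxygen on an aromatic ring with hydrogen in place of vinyl on a saturated chain carbon bound to an oxygen on an aromatic ring, which reads as allyl to methyl or allyloxy to methoxy. With compound 2 at 53.8 nM as the reference, no shift beyond the scatter is expected in this assay in either direction. The estimated step of a 1.1-fold lower number from compound 2 to compound 4 (0.03 log units; within the scatter) is expected to stay inside the scatter. The estimate for compound 4 is 50 nM with an expected range from 22 nM to 110 nM in this series.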

Compound 4, half-maximal inhibitory concentration: 52.1 nM
Estimate against measurement, compound 4: 1.0-fold (0.02 log units) below, and the stated range covers the measured number.
By their numbers in this assay, from the lowest: compounds 3, 4, 2 and 1 (each within the scatter of the next).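

In this assay, the series now has its first direct reading at this place: a 1.0-fold lower number from compound 2 to compound 4 (0.01 log units; within the scatter), for hydrogen in place of vinyl on a saturated chain carbon bound to an oxygen on an aromatic ring. In this one pair, cutting allyloxy back to methoxy leaves the read-out within the scatter, so the vinyl end is not needed to hold the number in this assay. No measured evidence bears on this result, and the flat step stays unexplained.

As far as these compounds go, whether the same flat reading holds for a longer chain such as butoxy, or for a chain ending in an amine or a carboxylic acid, stays open. A single pair also leaves open whether the change reads the same on any other core.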